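A Chloro on the Fused Ring of Compound 2

The compounds below may be only part of what the source reports. "The series", "measured", "known", "first", "only" and "open" are said of these compounds alone.

Compound 1 `Clc1ccc(-c2noc(-c3cc4ccccc4[nH]3)n2)cc1`: 19200 nM
Compound 2 `COc1ccc(-c2noc(-c3cc4ccccc4[nH]3)n2)cc1`: > 50000 nM
Compound 3 `COc1ccc(-c2noc(-c3cc4ccccc4n3C)n2)cc1`: 23100 nM

Three compounds sharing one core were tested in a functional assay on MIA PaCa-2 cells (Homo sapiens) for antiproliferative activity, read by WST assay, with a stated time of 72 h; on this read-out higher numbers stand for weaker inhibition and lower numbers for stronger inhibition. Compound 1 gives 19200 nM. For compound 2 the assay reports only a limit, > 50000 nM. Compound 3 gives 23100 nM. Two steps are known: an at least 2.6-fold higher number from compound 1 to compound 2 (0.41 log units; beyond the scatter) and an at least 2.1-fold lower number from compound 2 to compound 3 (0.33 log units; beyond the scatter). Both concern other positions of the core. Compound 4 `COc1ccc(-c2noc(-c3cc4cc(Cl)ccc4[nH]3)n2)cc1` differs from compound 2 by chloro in place of hydrogen on an aromatic carbon. Within the data shown here, no measured step probes a substituent on that fused ring, so no direction is firmly indicated, and the number of compound 4 is expected to stay near the limit of compound 2. Compound 4 is estimated at 35000 nM (range 10000 nM to 100000 nM), which would mean an expected step of an at least 1.4-fold lower number from compound 2 to compound 4 (0.15 log units; that floor lies within the scatter).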

Compound 4, half-maximal inhibitory concentration: 7800 nM
Compound 4: middle estimate off by 4.5-fold (0.65 log units), on the high side; the whole stated range lies above it.
By their numbers in this assay, from the lowest: compound 4; then compounds 1 and 3 (each within the scatter of the next). At a limit, above all of these: compound 2.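

On the fused ring, chloro in place of hydrogen gives an at least 6.4-fold lower number from compound 2 to compound 4 (0.80 log units; beyond the scatter) in this assay. Among these compounds, this ring carries no substituent in the earlier compounds, so this is the first sign that a single heavy atom on it can move the number beyond the scatter. The step is only a floor, and its full size cannot be read, because compound 2 stands at a limit: the limit of > 50000 nM in this assay, at which 1 of the 4 values shown sits.

On these data alone, what an amine or a carboxylic acid would do on that same carbon stays open. So does whether chloro on this ring would add to methyl on the aromatic nitrogen.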